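A few compounds are considered here, and "the series" means these few. Any claim that something is new, unique, unknown or untested is made for them only; others in the source may bear on it.

The measured compounds:
Compound 1, `CCCCN(c1nc2c(NC(C)=O)cccc2o1)[C@H](C)c1ccc(-c2ccccc2-c2nnn[nH]2)cc1`: 22 nM
Compound 2, `CCCCN(c1nc2c(C(=O)NC)cccc2o1)[C@H](C)c1ccc(-c2ccccc2-c2nnn[nH]2)cc1`: 110 nM
Compound 3, `CCCCN(c1nc2c(C(=O)N(C)C)cccc2o1)[C@H](C)c1ccc(-c2ccccc2-c2nnn[nH]2)cc1`: 13 nM

All three were tested in a functional assay on CAL1 cells for inhibition of chemerin-like receptor 1 (Homo sapiens), with a stated time of 45 min; on this read-out lower numbers stand for stronger inhibition and higher numbers for weaker inhibition. Compound 3 and compound 1 stand together at the low end, the step between them being a 1.7-fold lower number from compound 1 to compound 3 (0.23 log units; within the scatter), while compound 2 sits well above both: an 8.5-fold lower number from compound 2 to compound 3 (0.93 log units; beyond the scatter) and a 5.0-fold higher number from compound 1 to compound 2 (0.70 log units; beyond the scatter). The three share one core and differ only in the group carried on one aromatic carbon: acetamido in compound 1, methylcarbamoyl in compound 2, dimethylcarbamoyl in compound 3.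

Compound 4, `CCCCN(c1nc2c(-c3ccccn3)cccc2o1)[C@H](C)c1ccc(-c2ccccc2-c2nnn[nH]2)cc1`, has not yet been measured. It differs from compound 3 in a single place: pyridin-2-yl in place of dimethylcarbamoyl on an aromatic carbon. Within the data shown here, none of the measured steps swaps an amide-type group for an aromatic ring, so none bears directly on this change. Among the measured compounds shown here, what they do show is that the group at this position shifts the number by a modest amount at most, and that the only compound carrying a hydrogen-bond donor there, compound 2, gives the weakest result. Pyridin-2-yl brings no hydrogen-bond donor and keeps one hydrogen-bond acceptor. Compound 4 is therefore expected to give 30 nM, with a range from 8 nM to 120 nM. The expected step is a 2.3-fold higher number from compound 3 to compound 4 (0.36 log units; beyond the scatter), near the edge of the scatter.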

Compound 4, half-maximal inhibitory concentration: 110 nM
Estimate against measurement, compound 4: 3.7-fold (0.56 log units) below; the measured number falls inside the stated range.
By their numbers in this assay, from the lowest: compounds 3 and 1 (each within the scatter of the next); then compounds 2 and 4 (each within the scatter of the next).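

Putting an aromatic ring on this carbon gives a clear loss against the best amide-type group, with an 8.5-fold higher number from compound 3 to compound 4 (0.93 log units; beyond the scatter), even though dimethylcarbamoyl and pyridin-2-yl have the same counts of hydrogen-bond donors and acceptors, so those counts alone do not set the number at this position. The loss is about the same against acetamido, with a 5.0-fold higher number from compound 1 to compound 4 (0.70 log units; beyond the scatter), while methylcarbamoyl and pyridin-2-yl cannot be told apart, with no change at the digits printed from compound 2 to compound 4 (within the scatter). An aromatic ring and an amide-type group can therefore end up at the same level here, and absence of a hydrogen-bond donor on the group is no guarantee of a low number, as compound 4 goes against the pattern suggested by the first three compounds.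

Nothing in the available data explains why dimethylcarbamoyl and pyridin-2-yl differ at this carbon. The compounds shown leave open whether the loss belongs to aromatic rings here in general or to pyridin-2-yl alone, and whether phenyl, pyridin-3-yl or a simple amine on this carbon would fall nearer compound 3 or compound 4.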